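Hydroxamate series: cap change from compound 2 to compound 3

This account rests on a few compounds, and the source may have more. Where it says the series, first, only, none or still open, it means among the compounds named here.

Measured so far:
compound 1 `CCCN1CC(=O)N(Cc2ccc(C(=O)NO)cc2)C1=O`: 53.4 nM
compound 2 `O=C(NO)c1ccc(CN2C(=O)NC(Cc3ccc(Cl)cc3)(c3ccccc3)C2=O)cc1`: 54 nM

In an assay on isolated protein for inhibition of protein deacetylase HDAC6 (Homo sapiens), read by fluorescence, with stated times of 10 min and 2 h (on this read-out lower numbers stand for stronger inhibition and higher numbers for weaker inhibition), compound 1 gives 53.4 nM, and in the same assay compound 2 gives 54 nM. Compound 2 holds the higher of the two numbers, but its gap to compound 1 lies within the scatter, so the two read as equal. Going by the values given here, no pair of measured compounds differing in a single place is available, so no measured step guides the next change.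

Compound 3 `O=C(NO)c1ccc(CN2C(=O)NC(Cc3cccc4ccccc34)(c3ccccc3)C2=O)cc1` differs from compound 2 by naphthalen-1-yl in place of 4-chlorophenyl on a saturated chain carbon bound to a saturated ring carbon. Without a comparable step in hand, the step of a 1.1-fold lower number from compound 2 to compound 3 (0.03 log units; within the scatter) in this assay is expected to be none beyond the scatter. Compound 3 is estimated at 50 nM, with a range from 20 nM to 130 nM.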

Compound 3, half-maximal inhibitory concentration: 91.9 nM
The estimate for compound 3 lay 1.8-fold (0.26 log units) below the measured number, and the stated range covers the measured number.
By their numbers in this assay, from the lowest: compounds 1, 2 and 3 (each within the scatter of the next).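

In this assay naphthalen-1-yl in place of 4-chlorophenyl on a saturated chain carbon bound to a saturated ring carbon gives a 1.7-fold higher number from compound 2 to compound 3 (0.23 log units; within the scatter) and so stays within the scatter. This position therefore accepts the loss of the chlorine and the entry of a second six-membered aromatic ring, with 10 heavy atoms in place of 7, and no step beyond the scatter appears. Nothing at hand bears on the reason for this result.

The compounds shown leave open whether this position holds its number with a non-aromatic group, such as an amine or a carboxylic acid, in place of the aromatic ring. They also leave open what plain phenyl would give here, so the chlorine and the second ring cannot be judged apart.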